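Alkylating the Sulfur of a Triazole Thiol

This account rests on a few compounds, and the source may have more. Where it says the series, first, only, none or still open, it means among the compounds named here.

Compound 1, `COc1ccc(-n2c(S)nnc2-c2cc(OC)c(OC)c(OC)c2)cc1`: > 60000 nM in a functional assay on HT-29 cells (Homo sapiens) for inhibition, read by MTT assay, with a stated time of 48 h (a lower number here means a stronger inhibitor, a higher number a weaker inhibitor), a limit.
Compound 2, `COc1ccc(CSc2nnc(-c3cc(OC)c(OC)c(OC)c3)n2-c2ccc(OC)cc2)cc1`: > 60000 nM in this assay, a limit.

Compound 1 stands only at a limit: in this assay no number was obtained for compound 1, merely > 60000 nM. Compound 2 carries a 4-methoxybenzyl in place of hydrogen on a sulfur, and its result is likewise a limit. The step that the two limits leave unreadable from compound 1 to compound 2 cannot be read because of the limit of > 60000 nM in this assay, at which 2 of the 2 values shown sit. The unmeasured compound 3, `COc1ccc(-n2c(SCC(=O)C3CC3)nnc2-c2cc(OC)c(OC)c(OC)c2)cc1`, differs from compound 1 by (cyclopropylcarbonyl)methyl in place of hydrogen on a sulfur. Within the data shown here, the only measured step that bears on this change is the one from compound 1 to compound 2, and its size is not readable, so no direction can be taken from it. Compound 3 is therefore expected to remain near the limit, at about 60000 nM, within 10000 nM to 200000 nM. The expected step is a number no higher from compound 1 to compound 3 (the limit leaves the size open).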

Compound 3, half-maximal inhibitory concentration: > 60000 nM
Compound 3: no number, only a limit (the forecaster's own chance of this, stated with the estimate: 70%); the middle value lies on the limit itself.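

Compound 3 ends at a limit, just as compound 1 and compound 2 do, so none of the steps among these three compounds can be read: the limit of > 60000 nM in this assay, at which 3 of the 3 values shown sit.

The compounds shown leave open whether any group on the sulfur can give a readable number in this assay.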